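The compounds below may be only part of what the source reports. "The series", "measured", "known", "first", "only" and "open" are said of these compounds alone.

Compound 1 `COc1ccc(C2=NOC(C)(C)C2=O)cc1-c1cnc(NC(=O)c2c(F)cccc2F)cn1` and compound 2 `CCc1ccc(C2=NOC(C)(C)C2=O)cc1-c1cnc(NC(=O)c2c(F)cccc2F)cn1` share a core with compound 3 `Cc1ccc(C2=NOC(C)(C)C2=O)cc1-c1cnc(NC(=O)c2ccc(F)cc2F)cn1` but carry a different fluoro substitution on the amide-bearing ring. In an assay on Jurkat T cells for inhibition of interleukin-2 (Homo sapiens), read by ELISA, with stated times of 10 min and 24 h (on this read-out higher numbers stand for weaker inhibition and lower numbers for stronger inhibition), compound 1 gives 50 nM, and compound 2 gives 32 nM. Going by the values given here, the single change between those two is a 1.6-fold lower number from compound 1 to compound 2 (0.19 log units; within the scatter), ethyl in place of methoxy on an aromatic carbon, a move that does not stand out from repeated measurement. Compound 3 stands apart: in this assay compound 3 is reported as "not active" (no number reported), so no single number is available for it. Compound 4 `Cc1ccc(C2=NOC(C)(C)C2=O)cc1-c1cnc(NC(=O)c2ccccc2F)cn1` differs from compound 3 in one place: hydrogen in place of fluoro on an aromatic carbon. Among the compounds with values here, the one measured step, from methoxy to ethyl, concerns a different part of the molecule and a different fluoro pattern on the amide-bearing ring, so it offers no guide to removing a fluoro group there. Within the data shown here, the step from compound 3 to compound 4 thus has no measured counterpart, and neither the direction nor the size of any change in this assay can be read from these compounds. Given that compound 3 shows no measurable inhibition, compound 4 is expected to show at best weak inhibition, estimated at 5000 nM with a range from 500 nM to 50000 nM.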

Compound 4, half-maximal inhibitory concentration: "not active" (no number reported)
The entry for compound 4 holds no number; no gap can be computed for the estimate.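

In this assay, going by these compounds alone, compound 3 gives "not active" (no number reported) and compound 4 gives "not active" (no number reported) in the same way, so no step between these two compounds can be read. No measured evidence bears on this result. The compounds shown leave open whether going from 2,4-difluorophenyl to 2-fluorophenyl changes inhibition at all.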